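A few compounds are considered here, and "the series" means these few. Any claim that something is new, unique, unknown or untested is made for them only; others in the source may bear on it.

Measured so far in a functional assay on A2780 cells (Homo sapiens) for antiproliferative activity, read by MTT assay, with a stated time of 48 h; on this read-out lower numbers stand for stronger inhibition and higher numbers for weaker inhibition:
- compound 1 `COc1ccc(-c2cc3c(cn2)[nH]c(=O)n3-c2cc(OC)c(OC)c(OC)c2)cc1O`: 240 nM
- compound 2 `CCOc1ccc(-c2cc3c(cn2)[nH]c(=O)n3-c2cc(OC)c(OC)c(OC)c2)cc1`: 2980 nM

Compound 2 holds the higher of the two numbers and so sits at the weaker end of this short series. Within the data shown here, the only measured step, a 12-fold higher number from compound 1 to compound 2 (1.09 log units; beyond the scatter), puts 4-ethoxyphenyl in place of 3-hydroxy-4-methoxyphenyl on an aromatic carbon.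

Next is compound 3 `CCOc1ccc(-c2cc3c(cn2)[nH]c(=O)n3-c2cc(OC)c(OC)c(OC)c2)cc1F`, not yet measured. The change is fluoro in place of hydrogen on an aromatic carbon, ortho to an ethoxy group, turning 4-ethoxyphenyl into 4-ethoxy-3-fluorophenyl.

The step of a 12-fold higher number from compound 1 to compound 2 (1.09 log units; beyond the scatter) is large and concerns the same substituent, but it bears only indirectly, as it exchanges a hydroxy and a methoxy arrangement for an ethoxy one. Among the measured compounds shown here, no measured step isolates fluoro in place of hydrogen. A much smaller change is therefore expected in this assay, leaning slightly towards a lower number, and the estimate is a 1.7-fold lower number from compound 2 to compound 3 (0.22 log units; within the scatter).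

For compound 3 the expected value is 1800 nM, with an estimated range of 600 nM to 5000 nM.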

Compound 3, half-maximal inhibitory concentration: 4330 nM
Compound 3: the middle estimate sits 2.4-fold (0.38 log units) below what was measured; measured number inside the range.
By their numbers in this assay, from the lowest: compound 1; then compounds 2 and 3 (each within the scatter of the next).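

In this assay the fluoro group can now be read on its own: fluoro in place of hydrogen on an aromatic carbon, ortho to an ethoxy group, gives a 1.5-fold higher number from compound 2 to compound 3 (0.16 log units; within the scatter) and so leaves compound 3 level with compound 2 in this series. The gap to the 3-hydroxy-4-methoxyphenyl compound remains, with 4-ethoxy-3-fluorophenyl in place of 3-hydroxy-4-methoxyphenyl giving an 18-fold higher number from compound 1 to compound 3 (1.26 log units; beyond the scatter) and thus no return towards compound 1 at 240 nM from this single added fluoro group. No evidence on hand speaks to the reason for either reading.

Both steps away from compound 1 change the hydroxy and the alkoxy group together, so the part of the gap carried by the hydroxy group alone, and the part carried by methoxy against ethoxy, stay unresolved. Among these compounds, also open is how a chloro group, a nitrile or an amine on the same aromatic carbon would read, since a single fluoro group gives only one reading at this place, and on the 4-ethoxyphenyl background only.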